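Adding a Third Methoxy Group to Compound 2

The source may report more compounds than this note shows. Statements on the series, on what has been measured and on what is new or still open speak of the compounds shown alone.

Compound 1 `Nc1cc(N)c2nc(-c3ccccc3)c(NCc3ccc(Cl)c(Cl)c3)nc2c1` and compound 2 `COc1ccc(CNc2nc3cc(N)cc(N)c3nc2-c2ccccc2)cc1OC` share the same core and differ only in the aryl group carried on the saturated chain carbon bound to the ring nitrogen. In a functional assay on MDA-MB-435 cells (Homo sapiens) for inhibition, read by sulforhodamine B assay, with a stated time of 48 h (on this read-out higher numbers stand for weaker inhibition of growth and lower numbers for stronger inhibition of growth), compound 1 gives 2750 nM and compound 2 gives 1950 nM. The step of a 1.4-fold lower number from compound 1 to compound 2 (0.15 log units; within the scatter) is within the scatter, so the two values cannot be told apart; on the numbers shown compound 2 nonetheless stands at the lowest of the two, with compound 1 its only neighbour.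

Compound 3 `COc1cc(CNc2nc3cc(N)cc(N)c3nc2-c2ccccc2)cc(OC)c1OC` has not yet been measured. It differs from compound 2 by methoxy in place of hydrogen on an aromatic carbon. For the measured compounds named here, no measured step adds a single methoxy to this ring; the only step in hand, a 1.4-fold lower number from compound 1 to compound 2 (0.15 log units; within the scatter), exchanges 3,4-dichlorophenyl for 3,4-dimethoxyphenyl and stays within the scatter. Going by the values given here, with that as the sole guide, no step beyond the scatter in this assay is expected in either direction. Compound 3 is therefore estimated at 1800 nM, within 900 nM to 3800 nM, corresponding to an expected step of a 1.1-fold lower number from compound 2 to compound 3 (0.03 log units; within the scatter).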

Compound 3, concentration for 50% growth inhibition: 229 nM
Estimate against measurement, compound 3: 7.9-fold (0.90 log units) above; the whole stated range lies above it.
By their numbers in this assay, from the lowest: compound 3; then compounds 2 and 1 (each within the scatter of the next).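

Up to compound 2, changing the aryl group on the chain carbon had produced no readable difference in this assay: the exchange of 3,4-dichlorophenyl for 3,4-dimethoxyphenyl gave a 1.4-fold lower number from compound 1 to compound 2 (0.15 log units; within the scatter). For the compounds shown here, the single added methoxy group gives an 8.5-fold lower number from compound 2 to compound 3 (0.93 log units; beyond the scatter), the first step beyond the scatter and therefore the first sign that this aryl ring can affect the read-out. The position that matters here is the aromatic carbon ortho to a methoxy group and meta to a large group, where methoxy in place of hydrogen brings stronger inhibition of growth on the shared core, although nothing measured here accounts for the size of this step.

As far as these compounds go, this rests on one matched pair, so it remains open whether the change is specific to methoxy or would also appear with a hydroxyl group, a fluorine atom, an ethoxy group or an amine at the same carbon. Also open, from the compounds shown here alone, is whether the new methoxy group needs the two already present, which a compound carrying an ethoxy group in place of one of them would begin to test.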